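Cytotoxicity Outlook for a Pyrrolidinyl Analogue of Compound 2

The source may report more compounds than this note shows. Statements on the series, on what has been measured and on what is new or still open speak of the compounds shown alone.

Measured so far:
compound 1 `O=C(c1ccc(NCc2cncn2Cc2ccc(-c3ccccc3)cc2)cc1-c1ccccc1)N1CCCCC1` gives > 1000 nM
compound 2 `O=C(OC1CCCCC1)c1ccc(NCc2cncn2Cc2ccc(-c3ccccc3)cc2)cc1-c1ccccc1` gives > 10000 nM

In a toxicity assay on NIH3T3 cells (Mus musculus) for cytotoxicity, read by resazurin assay (on this read-out lower numbers stand for an effect already at smaller amounts and higher numbers for an effect only at larger amounts of compound), compound 1 reaches only a limit of the assay, (the limit of > 1000 nM in this assay, at which 1 of the 2 values shown sits). Compound 2 likewise reaches only a limit, (the limit of > 10000 nM in this assay, at which 1 of the 2 values shown sits). The step that the two limits leave unreadable from compound 1 to compound 2 is therefore not readable in size. Compound 3 `c1ccc(-c2ccc(Cn3cncc3CNc3ccc(N4CCCC4)c(-c4ccccc4)c3)cc2)cc1` differs from compound 2 by pyrrolidin-1-yl in place of cyclohexyloxycarbonyl on an aromatic carbon. For the measured compounds named here, no measured step bears on this change, so no step beyond the usual scatter is expected in either direction. Compound 3 is estimated at 15000 nM, with a range from 3000 nM to 60000 nM, most likely reported again as a limit. This estimate corresponds to an expected step that the limit leaves unreadable from compound 2 to compound 3.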

Compound 3, half-maximal effective concentration: > 1000 nM
Compound 3 gave a limit, no number; the forecaster's own chance of this, stated with the estimate: 70%; the middle value is on the limit's open side.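

For the compounds shown here, compound 3, like compound 1 and compound 2, reaches only a limit in this assay, and no step among the three can be read in size. The compounds shown leave open at what concentration any of them would take effect in this assay.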